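Solubility notes on a furan-3-yl analogue

This account rests on a few compounds, and the source may have more. Where it says the series, first, only, none or still open, it means among the compounds named here.

Working notes on the series built on the shared core of compound 1 `CNc1nc(NCCCN(C)C)c2sc(-c3ccc(-n4cccn4)cc3)cc2n1`. In a physicochemical assay for solubility, at pH 2 (on this read-out lower numbers stand for lower solubility and higher numbers for higher solubility), compound 1 gives 217 ug/mL. Compound 2 `CNc1nc(NCCCN(C)C)c2sc(-c3cccc(C#N)c3)cc2n1` reaches only a limit of the assay, > 100 ug/mL. Compound 3 `CNc1nc(NCCCN(C)C)c2sc(-c3ccc(OC)nc3)cc2n1` likewise reaches only a limit of the assay, > 100 ug/mL. The step that the two limits leave unreadable from compound 2 to compound 3 is therefore not readable in size, and the limit of > 100 ug/mL in this assay, at which 2 of the 3 values shown sit, is where two of the three values sit. Compound 4 `CNc1nc(NCCCN(C)C)c2sc(-c3ccoc3)cc2n1` differs from compound 3 by furan-3-yl in place of 6-methoxypyridin-3-yl on an aromatic carbon. Among the compounds with values here, no measured step of readable size bears on this change; the one neighbouring step is unreadable. For compound 4 the expected step that the limit leaves unreadable from compound 3 to compound 4 is none beyond the scatter. Compound 4 is estimated at 150 ug/mL in this assay, with a range from 50 ug/mL to 400 ug/mL.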

Compound 4, solubility: 221 ug/mL
For compound 4 the middle estimate is 1.5-fold (0.17 log units) below the measured one; the measured number falls inside the stated range.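

No new step can be read from compound 4 to compound 2 or compound 3, as the values of both are limits. In this assay how compound 2 and compound 3 truly compare with compound 4 stays open, given the limit: the limit of > 100 ug/mL in this assay, at which 2 of the 4 values shown sit.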